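A few compounds are considered here, and "the series" means these few. Any claim that something is new, unique, unknown or untested is made for them only; others in the source may bear on it.

Series notes on the nitrofuran amide set. Compound 1 `CC(=O)N1CC=C(c2ccn3c(-c4ccc(NC(=O)c5ccc([N+](=O)[O-])o5)cc4)cnc3c2)CC1` gives 940 nM in a functional assay on MGC-803 cells (Homo sapiens) for antiproliferative activity, read by CCK-8 assay, with a stated time of 72 h; a higher number here means a weaker inhibitor, a lower number a stronger inhibitor. Compound 2 `CN1CCN(c2ccn3c(-c4ccc(NC(=O)c5ccc([N+](=O)[O-])o5)cc4)cnc3c2)CC1` gives 1580 nM in this assay. Compound 3 `O=C(Nc1ccc(-c2cnc3cc(N4CCC4)ccn23)cc1)c1ccc([N+](=O)[O-])o1` reaches only the limit > 5000 nM in this assay, so no number is known for it; this is the limit of > 5000 nM in this assay, at which 1 of the 3 values shown sits. On the numbers shown, compound 3 therefore stands as the weakest of the three. The measured steps are a 1.7-fold higher number from compound 1 to compound 2 (0.23 log units; within the scatter), an at least 5.3-fold higher number from compound 1 to compound 3 (0.72 log units; beyond the scatter) and an at least 3.1-fold higher number from compound 2 to compound 3 (0.50 log units; beyond the scatter).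

Compound 4 `CN1CCCN(c2ccn3c(-c4ccc(NC(=O)c5ccc([N+](=O)[O-])o5)cc4)cnc3c2)CC1` is not yet measured. Its change from compound 3 is 4-methyl-1,4-diazepan-1-yl in place of azetidin-1-yl on an aromatic carbon. The step that bears on it most directly is an at least 3.1-fold higher number from compound 2 to compound 3 (0.50 log units; beyond the scatter), beyond the scatter and toward a higher number; the entering 4-methyl-1,4-diazepan-1-yl resembles the 4-methylpiperazin-1-yl of compound 2 far more than the azetidin-1-yl of compound 3, so the reverse direction, a lower number, is expected. Since a 1.7-fold higher number from compound 1 to compound 2 (0.23 log units; within the scatter) lay within the scatter, compound 4 is expected to land near compound 1 and compound 2 rather than at the limit. The expected step is an at least 2.7-fold lower number from compound 3 to compound 4 (0.44 log units; beyond the scatter). Compound 4 is estimated at 1800 nM, with a range from 800 nM to 4500 nM.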

Compound 4, half-maximal inhibitory concentration: 3580 nM
Beside the measured number, compound 4's estimate is 2.0-fold (0.30 log units) below it, and the stated range covers the measured number.
By their numbers in this assay, from the lowest: compounds 1 and 2 (each within the scatter of the next); then compound 4. At a limit, above all of these: compound 3.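

In this assay, among the compounds shown here, the seven-membered 4-methyl-1,4-diazepan-1-yl on this aromatic carbon, opposite the ring nitrogen, gives a weaker compound than the six-membered 4-methylpiperazin-1-yl, a ring-size change that the earlier compounds did not sample (a 2.3-fold higher number from compound 2 to compound 4 (0.36 log units; beyond the scatter)). The gap to the other six-membered ring is also beyond the scatter (a 3.8-fold higher number from compound 1 to compound 4 (0.58 log units; beyond the scatter)), so the closeness of the two six-membered rings does not carry over to the seven-membered ring. Against azetidin-1-yl only a floor within the scatter can be read (an at least 1.3-fold lower number from compound 3 to compound 4 (0.14 log units; that floor lies within the scatter)), its far end being a limit and not a number: (the limit of > 5000 nM in this assay, at which 1 of the 4 values shown sits).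

From the compounds shown here alone, how a morpholine or a pyrrolidine would read at this position stays open. Also open, going by these compounds, is how a piperazine with a free ring amine would compare with the 4-methylpiperazin-1-yl.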